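From a Sulfonium Side Chain to an Amine Side Chain

The source may hold more compounds than are shown below. What is called first, only, known or untested is meant among the compounds shown, and "the series" means these compounds.

Measured so far:
compound 1 `Cc1nc2c(N)ncnc2n1[C@@H]1O[C@H](C[S+](C)C)[C@@H](O)[C@H]1O` gives 3000 nM
compound 2 `CN(CCCCON)C[C@H]1O[C@@H](n2cnc3c(N)ncnc32)[C@H](O)[C@@H]1O` gives 18 nM
compound 3 `C[S+](C)C[C@H]1O[C@@H](n2cnc3c(N)ncnc32)[C@H](O)[C@@H]1O` gives 5000 nM
compound 4 `Cc1nc2c(N)ncnc2n1[C@@H]1O[C@H](CN(C)CCCN)[C@@H](O)[C@H]1O` is not yet measured

All four compounds share one core and differ in the side chain on the saturated chain carbon bound to a saturated ring carbon, and in one methyl on the core. In an assay on isolated protein for inhibition of S-adenosylmethionine decarboxylase proenzyme (Homo sapiens) (on this read-out lower numbers stand for stronger inhibition and higher numbers for weaker inhibition), compound 1 stands second highest of the three numbers: its nearest neighbour is compound 3, its furthest is compound 2. The methyl on an aromatic carbon matters little, as a 1.7-fold higher number from compound 1 to compound 3 (0.22 log units; within the scatter) shows. The side chain matters greatly: a 280-fold higher number from compound 2 to compound 3 (2.44 log units; beyond the scatter) is a large rise when an amine chain is replaced by a sulfonium group.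

Compound 4 takes the opposite direction from compound 1: a group of 6 heavy atoms (4 carbon, 2 nitrogen; no ring) in place of a group of 3 heavy atoms (2 carbon, 1 sulfur; no ring), on a saturated chain carbon bound to a saturated ring carbon. Compound 4 differs from compound 2 in the chain, so the gain of compound 2 may not fully carry over. Still, a large fall is expected in this assay. Compound 4 is estimated at 40 nM, between 8 nM and 250 nM, which would mean an expected step of a 75-fold lower number from compound 1 to compound 4 (1.88 log units; beyond the scatter).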

Compound 4, half-maximal inhibitory concentration: 70000 nM
Estimate against measurement, compound 4: 1800-fold (3.24 log units) below; the measured number lies above the stated range.
By their numbers in this assay, from the lowest: compound 2; then compounds 1 and 3 (each within the scatter of the next); then compound 4.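

On the core of compound 1, putting (3-aminopropyl)(methyl)amino in place of the sulfonium group weakens inhibition in this assay, with a 23-fold higher number from compound 1 to compound 4 (1.37 log units; beyond the scatter). Among the compounds shown here, an amine side chain on this saturated chain carbon therefore does not bring strong inhibition by itself, and the large earlier step, seen only with the chain of compound 2, cannot be read as a rule for every amine chain at this place. The change also replaces a group of net charge +1 with one of no net charge, but no measurement shown here explains the rise.

Compound 2 and compound 4 differ in both the chain and the methyl on an aromatic carbon, so these two changes cannot be separated. Also open, on these data alone, is how a longer chain ending in an amine, or a carboxylic acid, would behave at this place on the core of compound 1.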